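Swapping the Aryl Group on the Alkyne

This account rests on a few compounds, and the source may have more. Where it says the series, first, only, none or still open, it means among the compounds named here.

Within the data shown here, compound 2 `Cc1ccccc1C#Cc1ccc2c(n1)CCN(C(C)C)C2=O` is one of two compounds measured in a functional assay on HEK293 cells for negative allosteric modulation of metabotropic glutamate receptor 5 (Homo sapiens), read by FLIPR and calcium flux; a lower number here means a stronger inhibitor, a higher number a weaker inhibitor. There compound 2 gives 810 nM, the higher of the two numbers, while compound 1 `Cc1ccccc1C#Cc1ccc2c(n1)CCN(C)C2=O` gives 776 nM. The step of a 1.0-fold higher number from compound 1 to compound 2 (0.02 log units; within the scatter) shows that these two values cannot be told apart. Compound 3 `CC(C)N1CCc2nc(C#Cc3ccccn3)ccc2C1=O` differs from compound 2 at a different place: pyridin-2-yl in place of 2-methylphenyl on a triple-bonded carbon. Among the measured compounds shown here, the only measured step, from compound 1 to compound 2, changes the group on the amide-type nitrogen in the ring and leaves the aryl group on the alkyne untouched, so it says nothing about the swap at hand. No measured comparison bears on this change, so the expectation for compound 3 rests on the change alone and carries a wide range. Compound 3 is estimated at 600 nM, between 150 nM and 2500 nM. This is expected to amount to a step of a 1.4-fold lower number from compound 2 to compound 3 (0.13 log units; within the scatter).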

Compound 3, half-maximal inhibitory concentration: 27 nM
Beside the measured number, compound 3's estimate is 22-fold (1.35 log units) above it; the measured number lies below the stated range.
By their numbers in this assay, from the lowest: compound 3; then compounds 1 and 2 (each within the scatter of the next).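

This position matters far more than the group on the amide-type nitrogen. In this assay, pyridin-2-yl in place of 2-methylphenyl on the triple-bonded carbon gives a 30-fold lower number from compound 2 to compound 3 (1.48 log units; beyond the scatter), whereas the earlier change on the nitrogen gave a 1.0-fold higher number from compound 1 to compound 2 (0.02 log units; within the scatter). The swap brings in a ring nitrogen and removes a methyl in the same step, and no measured data explain the large effect of this change.

The compounds shown leave open whether plain phenyl would fall nearer compound 2 or compound 3, which would help separate the loss of the methyl from the gain of the ring nitrogen. As far as these compounds go, it also remains open whether pyridin-3-yl would match pyridin-2-yl, and whether methyl and isopropyl on the amide-type nitrogen would still stay level with pyridin-2-yl on the alkyne.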